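Predicting clearance after swapping an aryl sulfone substituent

A few compounds are considered here, and "the series" means these few. Any claim that something is new, unique, unknown or untested is made for them only; others in the source may bear on it.

Compounds measured so far:
- compound 1 `O=S(=O)(c1ccc(F)c(Cl)c1)c1cnc2c(F)cccc2c1-c1cccc(Cl)c1`: 0.18 mL/min
- compound 2 `O=S(=O)(c1ccc(F)c(F)c1)c1cnc2c(F)cccc2c1-c1ccc(Cl)cc1`: 0.28 mL/min
- compound 3 `COc1ccc(S(=O)(=O)c2cnc3c(F)cccc3c2-c2ccc(Cl)cc2)cc1`: 1.05 mL/min

In an ADME assay on microsomes from liver (Homo sapiens) for metabolic stability, tested at 2.5 uM (on this read-out lower numbers stand for slow clearance and higher numbers for fast clearance), compound 3 gives the highest number of the three, 1.05 mL/min. Its nearest neighbour is compound 2, which gives 0.28 mL/min, and the furthest is compound 1, which gives 0.18 mL/min; both gaps lie beyond the scatter. Going by the values given here, the step of a 3.8-fold higher number from compound 2 to compound 3 (0.57 log units; beyond the scatter) is the only measured step that changes a group on the sulfonyl sulfur.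

The next compound, compound 4 `O=S(=O)(c1ccc(F)c(Cl)c1)c1cnc2c(F)cccc2c1-c1ccc(Cl)cc1`, is built from compound 3 by this change: 3-chloro-4-fluorophenyl in place of 4-methoxyphenyl on a sulfonyl sulfur.

The step that bears on it is a 3.8-fold higher number from compound 2 to compound 3 (0.57 log units; beyond the scatter), which runs in the opposite direction to the present change. Among the compounds with values here, compound 1 also carries 3-chloro-4-fluorophenyl on the sulfonyl sulfur, but it differs from compound 4 elsewhere as well, so no step can be drawn between the two; what can be noted is only that compound 1 gives 0.18 mL/min. Compound 4 is therefore expected to give a lower number in this assay, with the step of a 4.8-fold lower number from compound 3 to compound 4 (0.68 log units; beyond the scatter) anticipated because a 3.8-fold higher number from compound 2 to compound 3 (0.57 log units; beyond the scatter) was reversed. The estimate for compound 4 is 0.22 mL/min, with a range from 0.1 mL/min to 0.5 mL/min.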

Compound 4, intrinsic clearance in a liver preparation (reported as CLH), per the amount of preparation that the assay uses: 0.01 mL/min
Compound 4: the middle estimate sits 22-fold (1.34 log units) above what was measured; the measured number lies below the stated range.
By their numbers in this assay, from the lowest: compound 4; then compounds 1 and 2 (each within the scatter of the next); then compound 3.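

Read in this assay, 3-chloro-4-fluorophenyl in place of 4-methoxyphenyl on the sulfonyl sulfur gives a 110-fold lower number from compound 3 to compound 4 (2.02 log units; beyond the scatter), so this change reaches much further than the earlier step on that sulfur, a 3.8-fold higher number from compound 2 to compound 3 (0.57 log units; beyond the scatter), had suggested. Going by these compounds alone, the two halogenated groups on the sulfur are also far from equivalent: chloro in place of fluoro on an aromatic carbon gives a 28-fold lower number from compound 2 to compound 4 (1.45 log units; beyond the scatter), showing that an exchange of one halogen at this position can produce a large step, where the earlier compounds showed only a change away from 4-methoxyphenyl. The group on the sulfur does not set the number alone, since with 3-chloro-4-fluorophenyl held constant, 4-chlorophenyl in place of 3-chlorophenyl on an aromatic carbon gives an 18-fold lower number from compound 1 to compound 4 (1.26 log units; beyond the scatter).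

Nothing given here explains the size of any of these steps. From the compounds shown here alone, it remains open whether the low number persists with other groups on the sulfonyl sulfur, such as a 3,4-dichlorophenyl, a pyridine ring or a phenyl carrying an amine, and whether the large chloro-for-fluoro step recurs when 3-chlorophenyl replaces 4-chlorophenyl on the shared core.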